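A few compounds are considered here, and "the series" means these few. Any claim that something is new, unique, unknown or untested is made for them only; others in the source may bear on it.

Series notes on a substituent comparison. Compound 1 `C(=C1\CCN=C1c1cccnc1)\c1ccccc1`, compound 2 `CN(C)c1ccc(/C=C2\CCN=C2c2cccnc2)cc1` and compound 3 `CN(C)c1ccc(/C=C/C=C2\CCN=C2c2cccnc2)cc1` have been run in an assay for displacement of a labelled ligand from Nicotinic acetylcholine receptor alpha8 subunit (Periplaneta americana), read by scintillation counting, with a stated time of 2 h, at 24 degrees C; a lower number here means a stronger inhibitor, a higher number a weaker inhibitor; compound 4 `C(=C/c1ccccc1)\C=C1/CCN=C1c1cccnc1` has not. Compound 2 gives 5490 nM in this assay. Compound 3 gives 2070 nM in this assay. For compound 1 the result in this assay is a limit, > 10000 nM, sitting at the limit of > 10000 nM in this assay, at which 1 of the 3 values shown sits. The change from compound 2 to compound 1 is hydrogen in place of dimethylamino on an aromatic carbon; it moves the number by an at least 1.8-fold higher number from compound 2 to compound 1 (0.26 log units; that floor lies within the scatter). Compound 3 and compound 2 differ in their cores, and that difference is not broken down here; of the two numbers, compound 3 holds the lower. Compound 4 arises from compound 3 by hydrogen in place of dimethylamino on an aromatic carbon, the same change at the same place. Given that the change from compound 2 to compound 1 measured an at least 1.8-fold higher number from compound 2 to compound 1 (0.26 log units; that floor lies within the scatter), compound 4 is expected to show a step of a 2.9-fold higher number from compound 3 to compound 4 (0.46 log units; beyond the scatter). The lower end of that earlier step lies within the scatter, so the expected size carries a wide range. For compound 4 the expected value in this assay is 6000 nM, between 2500 nM and 20000 nM, with a fair chance that only a limit is reported.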

Compound 4, half-maximal inhibitory concentration: 3520 nM
The estimate for compound 4 lay 1.7-fold (0.23 log units) above the measured number, and the stated range covers the measured number.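

Hydrogen in place of dimethylamino gives, in this assay, a 1.7-fold higher number from compound 3 to compound 4 (0.23 log units; within the scatter), a step that does not stand out from repeat measurements on the core concerned. Set beside the same change on the other core, the step offers no sign of a difference between the two, yet it cannot confirm agreement either: the same change on two cores in this assay, an at least 1.8-fold higher number (0.26 log units; that floor lies within the scatter) from compound 2 to compound 1 and a 1.7-fold higher number (0.23 log units; within the scatter) from compound 3 to compound 4; the limit leaves it open whether they differ
For compound 1, > 10000 nM is a limit of the assay, and these two cores alone establish neither a shared step size nor a core-dependent one.

Open, as far as these compounds go, is whether another group on that aromatic carbon, such as methoxy, a primary amine or a carboxylic acid, would give a number clearly apart from those of the dimethylamino and hydrogen pairs on either core. Also open, from the compounds shown here alone, is how the same change behaves on a core with a longer chain than that of compound 3.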